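This account rests on a few compounds, and the source may have more. Where it says the series, first, only, none or still open, it means among the compounds named here.

Measured so far:

Compound 1, `CC(C)(C)c1ccc(C(=O)N2CCC3(CC2)C(=O)N(CC(=O)NCCO)CN3c2ccccc2)cc1`, gives 1000 nM in an assay on HEK293 cells for displacement of a labelled ligand from NPC1-like intracellular cholesterol transporter 1 (Homo sapiens); on this read-out lower numbers stand for stronger inhibition and higher numbers for weaker inhibition.
Compound 2, `O=C(CN1CN(c2ccccc2)C2(CCN(C(=O)c3ccc(C4CCCCC4)cc3)CC2)C1=O)NCCO`, gives 2000 nM.
Compound 3, `CC(C)(C)OC(=O)NC1CCN(C(=O)CN2CN(c3ccccc3)C3(CCN(C(=O)c4ccc(C5CCCCC5)cc4)CC3)C2=O)CC1`, gives 4800 nM.

Among these three numbers compound 2 stands second highest. Its nearest neighbour is compound 1, separated by a 2.0-fold higher number from compound 1 to compound 2 (0.30 log units; within the scatter), a difference that does not exceed the usual scatter of repeated measurements, so the two cannot be told apart. Compound 3 lies further away, beyond the scatter, at the higher end.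

The unmeasured compound 4, `CC1(C)CC(OC(=O)CN2CN(c3ccccc3)C3(CCN(C(=O)c4ccc(C5CCCCC5)cc4)CC3)C2=O)CC(C)(C)N1`, is made from compound 2 by one change: (2,2,6,6-tetramethylpiperidin-4-yl)oxy in place of (2-hydroxyethyl)amino on a carbonyl carbon. Among the measured compounds shown here, the only step that has been measured, from compound 1 to compound 2, concerns a group on an aromatic carbon and not the carbonyl carbon changed here, so it gives little guidance. For the measured compounds named here, what can be said is that compound 3, which also carries a larger group in this region of the molecule, gives a higher number than compound 2, though no single step has been computed between those two. On that slender basis a modest rise is expected: a 1.8-fold higher number from compound 2 to compound 4 (0.24 log units; within the scatter). Compound 4 is therefore estimated at 3500 nM, with a likely range from 1200 nM to 10000 nM.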

Compound 4, half-maximal inhibitory concentration: 600 nM
Estimate against measurement, compound 4: 5.8-fold (0.77 log units) above; measured number below the stated range.
By their numbers in this assay, from the lowest: compounds 4, 1 and 2 (each within the scatter of the next, the first and the last beyond it); then compound 3.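

In this assay, (2,2,6,6-tetramethylpiperidin-4-yl)oxy in place of (2-hydroxyethyl)amino on this carbonyl carbon gives a 3.3-fold lower number from compound 2 to compound 4 (0.52 log units; beyond the scatter), the only step shown at this place, and it lies beyond the scatter. The entering group has 11 heavy atoms and a six-membered ring, while the leaving group has 4 heavy atoms and no ring, so a much larger group here can go with a lower number; size alone does not settle the outcome, as compound 3, with a different large group on the same kind of carbon, gives 4800 nM and compound 4 gives 600 nM in the same test. No measurement shown explains this step.

The step swaps the nitrogen on the carbonyl carbon for an oxygen and brings in the ring at the same time, and the compounds shown do not separate these two changes. Going by these compounds, a (2,2,6,6-tetramethylpiperidin-4-yl)amino group would keep the ring while restoring the nitrogen link, and a plain cyclohexyloxy group would keep the oxygen link while removing the ring nitrogen and its methyl groups, so the share of each part remains open.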